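A few compounds are considered here, and "the series" means these few. Any claim that something is new, unique, unknown or untested is made for them only; others in the source may bear on it.

Compound 3, `c1ccc(-c2cc[nH]n2)c(OCC2=NCCN2)c1`, stands at the edge of what the measurements can show. In a functional assay for activation of Alpha-1D adrenergic receptor (Homo sapiens), read by calcium flux (a higher number here means that more compound is needed for the effect, a lower number that less compound is needed), compound 3 gives < 100000 nM, which is a limit of the assay and not a number. Compound 1, `c1ccc(-c2ccncn2)c(OCC2=NCCN2)c1`, gives < 100000 nM, again a limit rather than a number. Compound 2, `c1csc(-c2ccccc2OCC2=NCCN2)c1`, gives 15.9 nM. Two of the three values sit at one limit (the limit of < 100000 nM in this assay, at which 2 of the 3 values shown sit), so the recorded steps are a step that the limit leaves unreadable from compound 1 to compound 2, a step that the two limits leave unreadable from compound 1 to compound 3 and a step that the limit leaves unreadable from compound 2 to compound 3; none of them has a readable size.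

The unmeasured compound 4, `Cc1ccoc1-c1ccccc1OCC1=NCCN1`, differs from compound 3 in one place: 3-methylfuran-2-yl in place of 1H-pyrazol-3-yl on an aromatic carbon. Going by the values given here, the only measured step along the same kind of change is a step that the limit leaves unreadable from compound 2 to compound 3, and its size is hidden by the limit. What remains is that compound 2 carries a five-membered ring with one hetero atom and no hydrogen-bond donor, as compound 4 will, and that compound 2 gives a clear number.

Compound 4 is expected to reach a readable value because compound 2 gives 15.9 nM. Compound 4 is therefore estimated at 60 nM, with a range from 8 nM to 1500 nM. Going by these compounds, the expected step is a step that the limit leaves unreadable from compound 3 to compound 4, toward less compound needed, though its true size stays open while compound 3 rests at a limit.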

Compound 4, half-maximal effective concentration: < 100000 nM
Compound 4: only a limit was reported (the forecaster's own chance of this, stated with the estimate: 15%); the middle value lies beyond the limit too.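

In this assay, going by these compounds alone, compound 4 gives < 100000 nM, which is a limit of the assay and not a number, so no step linking compound 4 with compound 1, compound 2 or compound 3 can be read. The compounds shown leave open how far compound 1, compound 3 and compound 4 truly lie from one another and from compound 2, the only one with a readable number.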